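Swapping the Aryl Group on a Triazole Sulfonamide

The source may hold more compounds than are shown below. What is called first, only, known or untested is meant among the compounds shown, and "the series" means these compounds.

Of the compounds shown here, three sharing one core have been tested in an ADME assay on GES1 cells (Homo sapiens) for cytotoxicity, read by MTT assay, with a stated time of 24 h; on this read-out lower numbers stand for higher toxicity in this test and higher numbers for lower toxicity in this test. Compound 1 `O=c1[nH]cc(S(=O)(=O)Nc2ccccc2-c2cn(-c3ccccc3)nn2)c(=O)[nH]1` carries an unsubstituted phenyl on the triazole nitrogen. Compound 2 `O=c1[nH]cc(S(=O)(=O)Nc2ccccc2-c2cn(-c3cccc(F)c3)nn2)c(=O)[nH]1` carries a 3-fluorophenyl in that place, and compound 3 `Cc1ccccc1-n1cc(-c2cccc(NS(=O)(=O)c3c[nH]c(=O)[nH]c3=O)c2)nn1` carries a 2-methylphenyl while also joining the triazole to the anilide ring at a different point. For compound 1 the read-out is only a limit of the assay, > 100000 nM, as summed up by the limit of > 100000 nM in this assay, at which 1 of the 3 values shown sits. For compound 2 the report in this assay says "not toxic" (no number reported), with no number given. Among the measured compounds shown here, compound 3 is the only one with a number in this assay, 21500 nM, so it stands alone and cannot be ranked against the others beyond noting that it gave a measurable value where the others did not.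

Compound 4 `O=c1[nH]cc(S(=O)(=O)Nc2cccc(-c3cn(-c4ccc(Cl)cc4)nn3)c2)c(=O)[nH]1` is still to be measured in this assay. It differs from compound 3 by 4-chlorophenyl in place of 2-methylphenyl on an aromatic nitrogen. For the measured compounds named here, because compounds 1, 2 and 3 each differ from one another in more than one place, no single measured step is available to lean on. A change from compound 3 to compound 4 that stays within the usual scatter, or lies only a little beyond it toward lower toxicity, is expected here, that is a 1.4-fold higher number from compound 3 to compound 4 (0.14 log units; within the scatter). Compound 4 is therefore estimated at 30000 nM, in a range from 10000 nM to 100000 nM.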

Compound 4, half-maximal cytotoxic concentration: 11300 nM
Compound 4: the middle estimate sits 2.7-fold (0.42 log units) above what was measured; measured number inside the range.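

In this assay, among the compounds shown here, the change on the aromatic nitrogen gives a 1.9-fold lower number from compound 3 to compound 4 (0.28 log units; within the scatter), and this is the first comparison that differs in one place only. With 2-methylphenyl and 4-chlorophenyl on the five-membered aromatic ring with 3 nitrogen, the two numbers cannot be told apart in this test, so moving from a methyl group to a chlorine and changing where it sits on the phenyl ring leaves no effect that can be separated from ordinary repeat-to-repeat variation. Nothing in the data shown bears on why the two compounds read alike.

From the compounds shown here alone, whether an amine or a carboxylic acid on this phenyl ring, or a longer chain in its place, would shift the number beyond the scatter stays open. Compound 1 offers only a limit of the assay, so what the other point of attachment between the triazole and the anilide ring does to the read-out also stays unresolved: the limit of > 100000 nM in this assay, at which 1 of the 4 values shown sits.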